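Halide swap on the hydrazone arm of a triazole series

The source may hold more compounds than are shown below. What is called first, only, known or untested is meant among the compounds shown, and "the series" means these compounds.

Measured compounds:
Compound 1 `Clc1ccc(CSc2nnc(-c3ccncc3)n2-c2ccccc2)cc1` — 10700 nM
Compound 2 `Brc1ccc(CSc2nnc(-c3ccncc3)n2-c2ccccc2)cc1` — 11100 nM
Compound 3 `O=C(CSc1nnc(-c2ccncc2)n1-c1ccccc1)N/N=C/c1ccc(Br)cc1` — 4500 nM

In a functional assay on HCT-116 cells (Homo sapiens) for inhibition, read by MTT assay, with a stated time of 48 h (on this read-out higher numbers stand for weaker inhibition and lower numbers for stronger inhibition), compound 2 gives 11100 nM and compound 1 gives 10700 nM. The step between them, a 1.0-fold lower number from compound 2 to compound 1 (0.02 log units; within the scatter), is chloro in place of bromo on an aromatic carbon. Compound 3 gives 4500 nM in this assay, the lowest of the three numbers; its nearest neighbour is compound 1. How the core of compound 3 differs from that of compound 2 is not broken down here.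

Compound 4 `O=C(CSc1nnc(-c2ccncc2)n1-c1ccccc1)N/N=C/c1ccc(Cl)cc1` is not yet measured. It differs from compound 3 by chloro in place of bromo on an aromatic carbon, the same change as that from compound 2 to compound 1, at the same kind of place. Since that earlier step, a 1.0-fold lower number from compound 2 to compound 1 (0.02 log units; within the scatter), stayed within the scatter, the step from compound 3 to compound 4 is expected to be small as well, about no change at the digits printed from compound 3 to compound 4 (within the scatter). On that basis compound 4 is estimated at 4500 nM in this assay, most likely between 2400 nM and 8500 nM.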

Compound 4, half-maximal inhibitory concentration: 5740 nM
Beside the measured number, compound 4's estimate is 1.3-fold (0.11 log units) below it, within the range that was stated.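

In this assay the change from 4-bromophenyl to 4-chlorophenyl on the hydrazone arm gives a 1.3-fold higher number from compound 3 to compound 4 (0.11 log units; within the scatter) and so leaves no measurable mark on this core. Set beside the earlier step, the same change behaves alike on both cores, with no difference that can be told from the scatter: the same change on two cores in this assay, a 1.0-fold lower number (0.02 log units; within the scatter) from compound 2 to compound 1 and a 1.3-fold higher number (0.11 log units; within the scatter) from compound 3 to compound 4, 1.3-fold (0.12 log units) apart, within the scatter of two such steps. Within the data shown here, this shows that the swap of these two halogens carried from one core to the other as a change too small to read, but it rests on only two pairs, makes no rule for the series, and does not show that a change with a larger step would carry across in the same way.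

The compounds shown hold only chloro and bromo at this place, so how a fluoro, a methoxy or a dimethylamino group there would read on either core remains open. Also open, from the compounds shown here alone, is whether the agreement between the two steps extends to cores other than these two or to other cell lines.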